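Amino for methyl on a furan-bearing nucleoside core

The compounds below may be only part of what the source reports. "The series", "measured", "known", "first", "only" and "open" are said of these compounds alone.

Measured so far:
- compound 1 `Nc1nc(N)c2c(-c3ccsc3)cn([C@@H]3O[C@H](CO)[C@@H](O)[C@H]3O)c2n1`: > 20000 nM
- compound 2 `Cc1nc(N)c2c(-c3ccoc3)cn([C@@H]3O[C@H](CO)[C@@H](O)[C@H]3O)c2n1`: > 100000 nM

Two nucleoside analogues have been tested in a functional assay on CCRF-CEM cells (Homo sapiens), read by MTT assay, with a stated time of 72 h; on this read-out lower numbers stand for stronger inhibition and higher numbers for weaker inhibition. Compound 1 `Nc1nc(N)c2c(-c3ccsc3)cn([C@@H]3O[C@H](CO)[C@@H](O)[C@H]3O)c2n1` shows only a limit, > 20000 nM. Compound 2 `Cc1nc(N)c2c(-c3ccoc3)cn([C@@H]3O[C@H](CO)[C@@H](O)[C@H]3O)c2n1` likewise shows only a limit, and a higher one, > 100000 nM. Neither gives a real number, so compound 2 stands at the weaker edge of what this assay can report, and nothing can be said about the gap to compound 1 beyond what the two limits show.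

Compound 3 `Nc1nc(N)c2c(-c3ccoc3)cn([C@@H]3O[C@H](CO)[C@@H](O)[C@H]3O)c2n1` has not yet been measured. It differs from compound 2 by amino in place of methyl on an aromatic carbon: the methyl leaves and an amino enters on the shared core. Compound 1 carries the same amino and gives > 20000 nM in this assay, so a stronger result for compound 3 is not expected with confidence; the step of an at least 2.0-fold lower number from compound 2 to compound 3 (0.30 log units; that floor lies within the scatter) is expected to be small or to stay hidden behind the assay limits. Compound 3 is estimated at 50000 nM, with a range from 8000 nM to 200000 nM.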

Compound 3, half-maximal inhibitory concentration: > 20000 nM
Compound 3: no number, only a limit; the forecaster's own chance of this, stated with the estimate: 75%; the middle value is on the limit's open side.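

Compound 3 gives only a limit, > 20000 nM. Compound 1 and compound 2 also show only limits, so the steps to compound 3 from either of them cannot be read. The compounds shown leave open what real value any of the three has, and whether amino in place of methyl or furan-3-yl in place of thiophen-3-yl changes it at all.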